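Replacing a pentyl chain with a chlorophenyl ring

The source may report more compounds than this note shows. Statements on the series, on what has been measured and on what is new or still open speak of the compounds shown alone.

Three compounds share one core and have been tested in a functional assay on MDA-MB-231 cells (Homo sapiens) for inhibition, read by MTT assay, with a stated time of 24 h, tested at 100 uM; a lower number here means less inhibition, a higher number more inhibition at the concentration tested (going by the name of the read-out):

Compound 1, `CCCCC/C=N/NC(=O)c1ccc(O[C@@H]2O[C@H](CO)[C@@H](O)[C@H](O)[C@H]2O)cc1`, gives 11%.
Compound 2, `O=C(N/N=C/c1cccc(Cl)c1)c1ccc(O[C@@H]2O[C@H](CO)[C@@H](O)[C@H](O)[C@H]2O)cc1`, gives 5.02%.
Compound 3, `COc1ccc(/C=N/NC(=O)c2ccc(O[C@@H]3O[C@H](CO)[C@@H](O)[C@H](O)[C@H]3O)cc2)cc1`, gives 11.3%.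

Among these three numbers compound 1 stands second highest. Its nearest neighbour is compound 3, a step of a number 0.3 percentage points higher from compound 1 to compound 3 (within the scatter), and its furthest is compound 2, a step of a number 6 percentage points lower from compound 1 to compound 2 (within the scatter); both steps lie within the scatter, so the three compounds cannot be ranked on these data.

The new compound 4, `O=C(N/N=C/c1ccc(Cl)cc1)c1ccc(O[C@@H]2O[C@H](CO)[C@@H](O)[C@H](O)[C@H]2O)cc1`, differs from compound 1 in one place: 4-chlorophenyl in place of pentyl on a carbon with a double bond to nitrogen.

Going by the values given here, two measured steps bear on this change, since both also exchange the pentyl chain for a substituted phenyl ring on the same carbon. From compound 1 to compound 2 the step was a number 6 percentage points lower from compound 1 to compound 2 (within the scatter), and from compound 1 to compound 3 it was a number 0.3 percentage points higher from compound 1 to compound 3 (within the scatter). Neither rose above the scatter, and the step between the two ring-bearing compounds, a number 6.3 percentage points higher from compound 2 to compound 3 (within the scatter), was likewise within it. A chlorophenyl ring with the chlorine in another position is therefore expected to give no step beyond the scatter in this assay, with an estimated step of a number 3 percentage points lower from compound 1 to compound 4 (within the scatter). Compound 4 is expected to give about 8%, within a range from 0% to 18%.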

Compound 4, a percentage reported as inhibition, at one concentration (the size of the read-out at that concentration, not a potency): 2.26%
Compound 4: middle estimate off by 5.7 percentage points, on the high side; the measured number falls inside the stated range.
By their numbers in this assay, from the lowest: compounds 4, 2, 1 and 3 (each within the scatter of the next).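

In this assay, the new compound adds a direct test of where the chlorine sits: exchanging 3-chlorophenyl for 4-chlorophenyl gives a step of a number 2.8 percentage points lower from compound 2 to compound 4 (within the scatter) and so separates neither compound from the other. Two further comparisons lead to the same reading, since 4-chlorophenyl in place of pentyl on a carbon with a double bond to nitrogen gives a number 8.7 percentage points lower from compound 1 to compound 4 (within the scatter) and chloro in place of methoxy on an aromatic carbon gives a number 9 percentage points lower from compound 3 to compound 4 (within the scatter), so neither the chain-to-ring exchange nor the exchange of the ring's substituent moves the read-out beyond the scatter in these compounds. No measurement is available to explain these numbers.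

Going by these compounds, whether a basic amine or a carboxylic acid on the ring, or a chain longer than pentyl on the same carbon, would give a step beyond the scatter remains open. The read-out also comes from a single concentration, so these four compounds leave their potencies unknown, and with them any ranking that a full concentration series might reveal.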